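Removing the Trifluoromethyl: Expected Cytotoxicity of Compound 3

This account rests on a few compounds, and the source may have more. Where it says the series, first, only, none or still open, it means among the compounds named here.

Compound 1, `O=C(/C=C/c1ccc2c(C(F)(F)F)cccc2n1)c1ccncc1`, gives 45400 nM in an ADME assay on A549 cells (Homo sapiens) for cytotoxicity; on this read-out lower numbers stand for stronger inhibition and higher numbers for weaker inhibition. Compound 2, `O=C(/C=C/c1ccc2c(C(F)(F)F)cccc2n1)c1cccnc1`, reaches only a limit of this assay, > 50000 nM.

Compound 2 therefore stands at the limit of > 50000 nM in this assay, at which 1 of the 2 values shown sits, with no number of its own. Compound 3, `O=C(/C=C/c1ccc2ccccc2n1)c1cccnc1`, differs from compound 2 by hydrogen in place of trifluoromethyl on an aromatic carbon. Among the measured compounds shown here, the single measured step, an at least 1.1-fold higher number from compound 1 to compound 2 (0.04 log units; that floor lies within the scatter), concerns the carbonyl side, not the trifluoromethyl, so no measured step bears on this change, and no step beyond the scatter is expected here. Compound 3 is therefore expected at about 60000 nM, between 20000 nM and 200000 nM, a change of a step that the limit leaves unreadable from compound 2 to compound 3, most likely again reported only as a limit.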

Compound 3, half-maximal inhibitory concentration: 21100 nM
Compound 3: the middle estimate sits 2.8-fold (0.45 log units) above what was measured; measured number inside the range.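

In this assay, the place held by trifluoromethyl on the aromatic carbon does matter: hydrogen there gives an at least 2.3-fold lower number from compound 2 to compound 3 (0.37 log units; beyond the scatter), so removing the group moves the number downward. The earlier step on the carbonyl side showed no floor beyond the scatter, whereas this one does. Its full size cannot be read, since compound 2 has only a limit and no number of its own: the limit of > 50000 nM in this assay, at which 1 of the 3 values shown sits.

From the compounds shown here alone, whether the same change would act alike with the pyridin-4-yl of compound 1 stays open. So does what a methyl group or a chlorine atom would give on that aromatic carbon.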